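The compounds below may be only part of what the source reports. "The series", "measured", "known", "first", "only" and "open" are said of these compounds alone.

Compound 1 `CC(=N)Nc1cccc(C(=O)NNC(=O)CC(CC(=O)O)c2ccc(Br)cc2)c1`: 2.27
Compound 2 `COc1ccc(C(CC(=O)O)CC(=O)NNC(=O)c2cccc(NC(C)=N)c2)cc1`: 1.31
Compound 3 `N=C(N)Nc1cccc(C(=O)NNC(=O)NC(CC(=O)O)c2ccc(Br)cc2)c1`: 1.53

Of the compounds shown here, three have been measured in a physicochemical assay for lipophilicity; on this read-out lower numbers stand for lower lipophilicity and higher numbers for higher lipophilicity. Compound 1 and compound 2 share a core and differ in one place: methoxy in place of bromo on an aromatic carbon. That change gave a number 0.96 log units lower from compound 1 to compound 2 (beyond the scatter). Compound 3 is built on a different core from compound 1; the difference between the two cores is not broken down here. In this assay compound 3 stands nearest to compound 2 and furthest from compound 1.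

Compound 4 `COc1ccc(C(CC(=O)O)NC(=O)NNC(=O)c2cccc(NC(=N)N)c2)cc1` has not yet been measured. It differs from compound 3 in one place: methoxy in place of bromo on an aromatic carbon. The place is described in the same words as for compound 1 and compound 2, so this is the same change. Because the same change gave a number 0.96 log units lower from compound 1 to compound 2 (beyond the scatter), compound 4 is expected to show a step of a number 0.93 log units lower from compound 3 to compound 4 (beyond the scatter) in this assay. Compound 4 is therefore estimated at 0.6 in this assay, with a likely range from 0.1 to 1.1.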

Compound 4, partition coefficient: 0.58
The estimate for compound 4 lay 0.02 log units above the measured number; the range from low to high includes it.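

In this assay the change gave a number 0.95 log units lower from compound 3 to compound 4 (beyond the scatter) and, on the core of compound 1, a number 0.96 log units lower from compound 1 to compound 2 (beyond the scatter) so the swap from 4-bromophenyl to 4-methoxyphenyl carried across these two cores with the same direction and nearly the same size. This rests on a single pair on each core, and it shows no general rule for other cores. Nothing measured here explains why the step has this size.

The compounds shown leave open how a chloro, an amine or a carboxylic acid in place of the bromo on that aromatic carbon would read in this assay and whether those steps would also carry between the two cores. As far as these compounds go, whether the methoxy step holds on any third core also remains open.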